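A few compounds are considered here, and "the series" means these few. Any claim that something is new, unique, unknown or untested is made for them only; others in the source may bear on it.

Measured compounds in this series:
compound 1 `COc1ccc(-c2cc(/C=C/C(=O)c3ccc(N)cc3)[nH]n2)cc1` — 92%
compound 2 `COc1cc(-c2cc(/C=C/C(=O)c3ccc(N)cc3)[nH]n2)cc(OC)c1OC` — 89%
compound 3 `COc1ccc(C(=O)/C=C/c2cc(-c3cc(OC)c(OC)c(OC)c3)n[nH]2)cc1` — 95%

In a functional assay on OVCAR-5 cells (Homo sapiens) for cytotoxicity, read by sulforhodamine B assay, with a stated time of 48 h, tested at 1 uM (a lower number here means a stronger effect, a higher number a weaker effect of the compound at the concentration tested), compound 2 gives 89%, the lowest of the three numbers, although all three lie within the usual scatter of one another. Compound 1 stands nearest; compound 3 stands furthest, with a number 6 percentage points higher from compound 2 to compound 3 (within the scatter).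

Compound 4 `COc1ccc(-c2cc(/C=C/C(=O)c3ccc(N)cc3)[nH]n2)cc1OC` differs from compound 2 by hydrogen in place of methoxy on an aromatic carbon. Going by the values given here, no measured step removes a methoxy from this ring, so no direct precedent exists. Among the compounds with values here, the only measured step, from compound 2 to compound 3, concerns the other aromatic ring and stays within the scatter. Compound 1, which also carries methoxy on the ring in question, gives 92%, close to compound 2. Nothing in these numbers therefore points to a step in this assay beyond the scatter in either direction.

Compound 4 is expected to give about 90%, in the range 80% to 98%, which means an estimated step of a number 1 percentage points higher from compound 2 to compound 4 (within the scatter).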

Compound 4, a percentage reported as activity, at one concentration (the size of the read-out at that concentration, not a potency): 94%
The estimate for compound 4 lay 4 percentage points below the measured number; measured number inside the range.
By their numbers in this assay, from the lowest: compounds 2, 1, 4 and 3 (each within the scatter of the next).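

In this assay, removing a methoxy from this ring gives a number 5 percentage points higher from compound 2 to compound 4 (within the scatter), and adding one to the ring of compound 1 gives a number 2 percentage points higher from compound 1 to compound 4 (within the scatter). Going by these compounds alone, the earlier compounds offered only a single step, on the other aromatic ring; these two steps are the first on the methoxy-bearing ring itself. Hydrogen and methoxy at these places cannot be told apart in this read-out at this concentration, in either direction of the exchange.

On these data alone, whether a hydroxyl, a fluorine or an amine on this ring would give a step beyond the scatter in this assay stays open. So does how these compounds would read at any other concentration. No measurement here offers an explanation for the closeness of these numbers.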